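A few compounds are considered here, and "the series" means these few. Any claim that something is new, unique, unknown or untested is made for them only; others in the source may bear on it.

Measured so far in a physicochemical assay for solubility; a higher number here means a more soluble compound, a lower number a less soluble compound:
- Compound 1 `CNC(=O)c1cc(C(=O)N[C@H]2[C@@H]3C[C@@H](OC)C[C@@H]32)n([C@@H](C)c2ccccc2)n1`: >= 150 ug/mL, a limit
- Compound 2 `CNC(=O)c1cc(C(=O)N[C@H]2CC[C@H](O)CC2)n([C@@H](C)c2ccccc2)n1`: >= 180 ug/mL, a limit
- Compound 3 `CNC(=O)c1cc(C(=O)N[C@H]2CC[C@H](OC)CC2)n([C@@H](C)c2ccccc2)n1`: >= 161 ug/mL, a limit

Compound 3 has no exact number, only its limit of >= 161 ug/mL, and the other two compounds likewise have only limits. The next change leads to compound 4 `CNC(=O)c1cc(C(=O)NC(C)CO)n([C@@H](C)c2ccccc2)n1` and sits on an amide-type nitrogen: 1-(hydroxymethyl)ethyl in place of 4-methoxycyclohexyl on an amide-type nitrogen.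

Going by the values given here, three measured steps bear on it: a step that the two limits leave unreadable from compound 1 to compound 2, a step that the two limits leave unreadable from compound 1 to compound 3 and a step that the two limits leave unreadable from compound 2 to compound 3. None of their sizes can be read, and none of them opens the ring into a chain, so this is weak guidance. No change beyond the usual scatter is expected. The expected move is a step that the limit leaves unreadable from compound 3 to compound 4. For compound 4 the estimate is 170 ug/mL, with an expected range of 90 ug/mL to 320 ug/mL.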

Compound 4, solubility: >= 132 ug/mL
Compound 4: a limit, no number (the forecaster's own chance of this, stated with the estimate: 75%); the middle value lies beyond the limit too.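

In this assay compound 4 gives only a limit, >= 132 ug/mL. Going by these compounds alone, compound 1, compound 2 and compound 3 also have only limits, so no step from them to compound 4 can be read. The compounds shown leave open how far solubility differs among these groups on the amide-type nitrogen.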